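Swapping trifluoromethyl for chloro on the benzoyl ring

The source may report more compounds than this note shows. Statements on the series, on what has been measured and on what is new or still open speak of the compounds shown alone.

Measured so far in a functional assay on MCF7 cells (Homo sapiens) for cytotoxicity, read by MTT assay, with a stated time of 48 h; a lower number here means a stronger inhibitor, a higher number a weaker inhibitor:
compound 1, `COc1cc(-c2nnc3n2NC(c2ccco2)C(C(=O)c2ccco2)S3)cc(OC)c1OC`: > 100000 nM
compound 2, `COc1cc(-c2nnc3n2NC(c2cccs2)C(C(=O)c2ccc(Cl)cc2)S3)cc(OC)c1OC`: 42800 nM
compound 3, `COc1cc(-c2nnc3n2NC(c2ccco2)C(C(=O)c2ccc(C(F)(F)F)cc2)S3)cc(OC)c1OC`: 33600 nM

The value of compound 1 is a limit of the assay, not a number. Compound 3 has the lowest of the two numbers that were obtained; compound 2 stands nearest to it, within the scatter, so no order between the two can be claimed.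

Going by the values given here, the one measured step on a single change is an at least 2.9-fold lower number from compound 1 to compound 3 (0.47 log units; beyond the scatter), bounded by the limit of > 100000 nM in this assay, at which 1 of the 3 values shown sits. It concerns the group on the carbonyl carbon, not the substituent on the phenyl ring, so it does not directly test the change now in view.

Compound 4, `COc1cc(-c2nnc3n2NC(c2ccco2)C(C(=O)c2ccc(Cl)cc2)S3)cc(OC)c1OC`, differs from compound 3 by chloro in place of trifluoromethyl on an aromatic carbon. Compound 2 carries the same 4-chlorophenyl carbonyl as compound 4 and gives a number close to that of compound 3, but it also differs from compound 4 elsewhere, so its value is only a rough guide.

Among the compounds with values here, with no measured step matching this change and the nearest comparison within the scatter, no step beyond the scatter is expected: compound 4 is estimated at 40000 nM, with a range from 15000 nM to 110000 nM, the expected step being a 1.2-fold higher number from compound 3 to compound 4 (0.08 log units; within the scatter).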

Compound 4, half-maximal inhibitory concentration: > 100000 nM
Compound 4: only a limit was reported (the forecaster's own chance of this, stated with the estimate: 15%); middle value at least 2.5-fold (0.39 log units) from the limit.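

Going by these compounds alone, replacing trifluoromethyl with chloro on the aromatic carbon gives an at least 2.9-fold higher number from compound 3 to compound 4 (0.47 log units; beyond the scatter) in this assay, and everything else in the two structures stays the same, so this is the first direct sign that the substituent at this place affects the read-out. Chloro alone does not settle the outcome, as moving to furan-2-yl on the saturated ring carbon while keeping the 4-chlorophenyl carbonyl gives an at least 2.3-fold higher number from compound 2 to compound 4 (0.36 log units; beyond the scatter), so the effect of this substituent may depend on the group elsewhere in the molecule. The value of compound 4 is a limit of the assay, so these two steps show only a smallest size, and the step from compound 1 cannot be read, as both of its ends are limits: the limit of > 100000 nM in this assay, at which 2 of the 4 values shown sit.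

The compounds shown leave open how far compound 4 really lies from compound 3, and whether a different group at this place, such as a nitrile, a methoxy group or an amine, would give a readable number with furan-2-yl on the saturated ring carbon. They also leave open how trifluoromethyl behaves when thiophen-2-yl sits on that ring carbon instead.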